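Shortening the side chain from compound 3 to compound 4

This account rests on a few compounds, and the source may have more. Where it says the series, first, only, none or still open, it means among the compounds named here.

Values in a functional assay on HL-60 cells (Homo sapiens) for cytotoxicity, read by WST assay, with a stated time of 48 h; on this read-out lower numbers stand for stronger inhibition and higher numbers for weaker inhibition:
- compound 1 `COc1cc(C(c2ccc(O)c(OC)c2)[C@H](C)[C@H](C)CO)ccc1O` gives > 100000 nM (a limit)
- compound 2 `CCCCCCCC[C@H](C(C)C)C(c1ccc(O)c(OC)c1)c1ccc(O)c(OC)c1` gives 3700 nM
- compound 3 `COC[C@@H](C)[C@@H](C)C(c1ccc(O)c(OC)c1)c1ccc(O)c(OC)c1` gives 85000 nM

Of the two true numbers, compound 3 is the higher, with 85000 nM against compound 2 with 3700 nM in this assay, a gap beyond the scatter. Compound 1 stands at > 100000 nM as a limit, not a number. Among the measured compounds shown here, the only measured single change is an at least 1.1-fold lower number from compound 1 to compound 3 (0.07 log units; that floor lies within the scatter) and it offers little guidance.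

Compound 4 `CC[C@H](C(C)C)C(c1ccc(O)c(OC)c1)c1ccc(O)c(OC)c1` carries 1-isopropylpropyl in place of 2-(methoxymethyl)-1-methylpropyl on a saturated chain carbon bound to two aromatic carbons, a change counted as 1-isopropylpropyl in place of 2-(methoxymethyl)-1-methylpropyl on a saturated chain carbon bound to two aromatic carbons and leaving no oxygen in that chain. Compound 2 at 3700 nM also has no oxygen there but a longer chain, so a moderately lower number than for compound 3 is expected in this assay, probably not reaching that of compound 2. The estimated step is a 2.8-fold lower number from compound 3 to compound 4 (0.45 log units; beyond the scatter) in size. Compound 4 is estimated at 30000 nM, with an expected range from 8000 nM to 90000 nM.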

Compound 4, half-maximal inhibitory concentration: 16000 nM
The estimate for compound 4 lay 1.9-fold (0.27 log units) above the measured number; measured number inside the range.
By their numbers in this assay, from the lowest: compound 2; then compound 4; then compound 3. At a limit, above all of these: compound 1.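

In this assay, among the compounds shown here, the swap of 2-(methoxymethyl)-1-methylpropyl for 1-isopropylpropyl gives the first step at this position that clearly exceeds the scatter (a 5.3-fold lower number from compound 3 to compound 4 (0.73 log units; beyond the scatter)). Among the chains without oxygen, length also matters: hydrogen in place of hexyl gives a higher number (a 4.3-fold higher number from compound 2 to compound 4 (0.64 log units; beyond the scatter)). The step from the 2-(hydroxymethyl)-1-methylpropyl chain is only a floor (an at least 6.2-fold lower number from compound 1 to compound 4 (0.79 log units; beyond the scatter)), since compound 1 stands at a limit: the limit of > 100000 nM in this assay, at which 1 of the 4 values shown sits.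

The compounds shown leave open whether the lower number of compound 4 follows from losing the oxygen or from the other differences in the chain. They also leave open how an amine or a carboxylic acid on this chain would read.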